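Swapping bromine for fluorine on the benzyl ring

The source may report more compounds than this note shows. Statements on the series, on what has been measured and on what is new or still open speak of the compounds shown alone.

Of the compounds shown here, three share one core and have been tested in a functional assay on MIA PaCa-2 cells (Homo sapiens) for inhibition, read by MTT assay, with a stated time of 48 h, tested at 10 uM; a lower number here means less inhibition of growth, a higher number more inhibition of growth at the concentration tested. Compound 1 `O=C(/C=C/c1ccc(OCc2cn(Cc3ccccc3Br)nn2)cc1)c1ccc(Br)cc1` gives 43% in this assay. Compound 2 `O=C(/C=C/c1ccc(OCc2cn(Cc3cccc(Br)c3)nn2)cc1)c1ccc(Br)cc1` gives 43%. Compound 3 `COc1ccc(C(=O)/C=C/c2ccc(OCc3cn(Cc4ccccc4Br)nn3)cc2)cc1` gives 50%, the highest of the three numbers, though its gap to each of the others lies within the usual scatter, so none of them can be called the more active. The steps seen so far are small: no change at the digits printed from compound 1 to compound 2 (within the scatter), and a number 7 percentage points higher from compound 1 to compound 3 (within the scatter).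

Compound 4 `COc1ccc(C(=O)/C=C/c2ccc(OCc3cn(Cc4ccccc4F)nn3)cc2)cc1` is not yet measured. It differs from compound 3 by one change: fluoro in place of bromo on an aromatic carbon. Within the data shown here, no measured step swaps one halogen for another on this ring. The closest guide is the move of the bromine from one position to another on the same benzyl ring, which gave no change from compound 1 to compound 2, and the methoxy-for-bromo exchange on the other ring, which also stayed within the scatter. With so little movement across the set, compound 4 is expected to give about 47% in this assay, between 35% and 60%. The expected step of a number 3 percentage points lower from compound 3 to compound 4 (within the scatter) is therefore none beyond the scatter.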

Compound 4, percent growth inhibition at one concentration: 19%
Compound 4: the middle estimate sits 28 percentage points above what was measured; the measured number lies below the stated range.
By their numbers in this assay, from the lowest: compound 4; then compounds 1, 2 and 3 (each within the scatter of the next).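

In this assay, changing 2-bromobenzyl to 2-fluorobenzyl gives a number 31 percentage points lower from compound 3 to compound 4 (beyond the scatter) and so shows that the identity of the halogen at this place on the benzyl ring matters. Among these compounds, the only earlier change on this ring, moving the bromine, gave no change at the digits printed from compound 1 to compound 2 (within the scatter) and made the ring look as if it tolerated change, but that step kept the bromine and therefore could not test this. The exchange replaces one heavy atom with another, with no change in the counted hydrogen-bond donors, hydrogen-bond acceptors or net charge, and no measurement available here explains why the number falls so far.

Going by these compounds, this exchange is seen in a single pair of compounds, so it remains open whether fluoro in place of bromo would lower the number in the same way with the bromo group of compound 1 on the other ring. Also open, on these data alone, is where a chloro or a methyl group at this same place would fall, and whether moving the fluorine around the ring, as the bromine was moved in compound 2, would leave the number unchanged.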